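This account rests on a few compounds, and the source may have more. Where it says the series, first, only, none or still open, it means among the compounds named here.

Measured compounds:
compound 1, `CC[C@H]1CN(c2ncc(C#N)cc2Cl)CCN1C1CCN(Cc2ccc(Cl)cc2F)CC1`, 50.5 nM
compound 2, `CC[C@H]1CN(c2ncc(-c3nnc[nH]3)cc2Cl)CCN1C1CCN(Cc2ccc(Cl)cc2F)CC1`, 6.8 nM
compound 3, `CC[C@H]1CN(c2ncc(-c3noc(=O)[nH]3)cc2Cl)CCN1C1CCN(Cc2ccc(Cl)cc2F)CC1`, 760 nM

All three were tested in an assay on isolated protein for binding affinity to C-X-C chemokine receptor type 3 (Homo sapiens); a lower number here means a stronger inhibitor, a higher number a weaker inhibitor. Compound 2 gives the lowest number of the three: a 7.4-fold lower number from compound 1 to compound 2 (0.87 log units; beyond the scatter), and a 110-fold higher number from compound 2 to compound 3 (2.05 log units; beyond the scatter), so compound 2 stands as the strongest binder among the measured compounds, with both steps beyond the scatter.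

Compound 4, `CC[C@H]1CN(c2ncc(-c3ncon3)cc2Cl)CCN1C1CCN(Cc2ccc(Cl)cc2F)CC1`, is not yet measured. It differs from compound 2 in one place: 1,2,4-oxadiazol-3-yl in place of 4H-1,2,4-triazol-3-yl on an aromatic carbon.

For the measured compounds named here, two measured steps touch the same position and bear on this change. The step of a 7.4-fold lower number from compound 1 to compound 2 (0.87 log units; beyond the scatter) shows that putting a five-membered aromatic ring with 3 hetero atoms at this carbon can strengthen binding considerably relative to the nitrile. The step of a 110-fold higher number from compound 2 to compound 3 (2.05 log units; beyond the scatter) shows that a different five-membered ring with 3 hetero atoms, but with 2 oxygen atoms, loses far more than that. Going by the values given here, the oxadiazole of compound 4 keeps the ring size and hetero atom count of compound 2 but gives up the hydrogen-bond donor; no measured pair isolates that loss. Compound 4 is therefore expected to sit between compound 2 and compound 1, and the estimated step is a 4.4-fold higher number from compound 2 to compound 4 (0.64 log units; beyond the scatter). The estimate for compound 4 in this assay is 30 nM, with a range from 8 nM to 120 nM.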

Compound 4, half-maximal inhibitory concentration: 286 nM
Beside the measured number, compound 4's estimate is 9.5-fold (0.98 log units) below it, outside the stated range (above it).
By their numbers in this assay, from the lowest: compound 2; then compound 1; then compound 4; then compound 3.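

In this assay the change keeps the ring size and the heavy atom count, yet a 42-fold higher number from compound 2 to compound 4 (1.62 log units; beyond the scatter) so the gain seen with compound 2 does not come with every five-membered aromatic ring with 3 hetero atoms on this aromatic carbon. The oxadiazole does not even hold the level of the nitrile, as a 5.7-fold higher number from compound 1 to compound 4 (0.75 log units; beyond the scatter) and this leaves the 4H-1,2,4-triazol-3-yl of compound 2 as the only ring shown here that improves on the nitrile. The last comparison, a 2.7-fold lower number from compound 3 to compound 4 (0.42 log units; beyond the scatter) adds that a ring hydrogen on nitrogen does not suffice on its own, since compound 3 carries one and still gives the higher number, while the 1,2,4-oxadiazol-3-yl has 0 hydrogen-bond donors.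

Nothing measured here accounts for these differences.

As far as these compounds go, whether compound 2 owes its strength to its ring hydrogen or to its ring nitrogens stays open, and a methyl group on that triazole nitrogen would separate the two. From the compounds shown here alone, how a tetrazole or an imidazole on this aromatic carbon would rank against the triazole also remains unknown.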